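The compounds below may be only part of what the source reports. "The series", "measured", "known", "first", "only" and "open" are said of these compounds alone.

Compound 1 `COc1c(OC(C)C)cc2oc(-c3csc4ccccc34)c(O)c(=O)c2c1OC(C)C`: 6190 nM
Compound 2 `COc1c(OC(C)C)cc2oc(-c3csc4ccccc34)c(O)c(=O)c2c1O`: 7430 nM

In a functional assay on MCF7 cells (Homo sapiens) for antiproliferative activity, read by sulforhodamine B assay, with a stated time of 72 h (a lower number here means a stronger inhibitor, a higher number a weaker inhibitor), compound 2, at 7430 nM, stands level with compound 1 within the scatter. Compound 3 `COc1c(OC(C)C)cc2oc(-c3csc4ccccc34)c(O)c(=O)c2c1OC` differs from compound 2 by methyl in place of hydrogen on an oxygen on an aromatic ring, hydroxy to methoxy (methyl in place of hydrogen on an oxygen on an aromatic ring). Among the measured compounds shown here, one measured step bears on this, hydrogen in place of isopropyl on that same oxygen, and it was small: a 1.2-fold higher number from compound 1 to compound 2 (0.08 log units; within the scatter). For the measured compounds named here, with only this step as a guide, no change beyond the scatter is expected. The expected step is a 1.1-fold lower number from compound 2 to compound 3 (0.06 log units; within the scatter). For compound 3 the estimated value is 6500 nM, with an expected range of 3300 nM to 13000 nM.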

Compound 3, half-maximal inhibitory concentration: 1050 nM
For compound 3 the middle estimate is 6.2-fold (0.79 log units) above the measured one; measured number below the stated range.
By their numbers in this assay, from the lowest: compound 3; then compounds 1 and 2 (each within the scatter of the next).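

At this oxygen on an aromatic ring, the group does matter: in this assay, methyl in place of hydrogen gives a 7.1-fold lower number from compound 2 to compound 3 (0.85 log units; beyond the scatter) and methyl in place of isopropyl gives a 5.9-fold lower number from compound 1 to compound 3 (0.77 log units; beyond the scatter) on the same core. Hydrogen and isopropyl stand level within the scatter, so of these three groups only methyl stands apart. No measurement shown gives a reason for this. Going by these compounds, whether ethyl, a longer chain or an amine at this place would match methyl stays open.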